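This account rests on a few compounds, and the source may have more. Where it says the series, first, only, none or still open, it means among the compounds named here.

Compound 1 `CC(C)c1ccc(-n2nc(-c3ccc(C(F)(F)F)cc3O)nc2-c2ccccc2O)cc1` is the starting point of this account. In a functional assay on PC-12 cells (Rattus norvegicus) for cytotoxicity, read by MTT assay, with stated times of 2 h and 24 h, tested at 1 uM (on this read-out lower numbers stand for a weaker effect and higher numbers for a stronger effect at the one concentration tested), compound 1 gives 69.7%. Within the data shown here, its one measured neighbour, compound 2 `Oc1cc(C(F)(F)F)ccc1-c1nc(-c2ccccc2O)n(-c2ccccc2F)n1`, gives 63.4% in this assay, and the two compounds sit within the scatter of each other: a number 6.3 percentage points lower from compound 1 to compound 2 (within the scatter). Compound 3 `Oc1cc(C(F)(F)F)ccc1-c1nc(-c2ccccc2O)n(-c2cccc(Cl)c2)n1` has not yet been measured; it differs from compound 1 in one place, (3-chlorophenyl in place of 4-isopropylphenyl on an aromatic nitrogen). Among the measured compounds shown here, the only step that bears on this change is the one from compound 1 to compound 2, where another group on the same aromatic nitrogen left the number within the scatter, so no step beyond the scatter is expected here. Compound 3 is therefore estimated at 65%, between 50% and 80%, meaning an expected step of a number 4.7 percentage points lower from compound 1 to compound 3 (within the scatter).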

Compound 3, a percentage reported as activity, at one concentration (the size of the read-out at that concentration, not a potency): 72.3%
Compound 3: the middle estimate sits 7.3 percentage points below what was measured; the measured number falls inside the stated range.
By their numbers in this assay, from the lowest: compounds 2, 1 and 3 (each within the scatter of the next).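

With 3-chlorophenyl on the aromatic nitrogen, the two new steps are a number 2.6 percentage points higher from compound 1 to compound 3 (within the scatter) and a number 8.9 percentage points higher from compound 2 to compound 3 (within the scatter) and neither goes beyond the scatter. Across compounds 1, 2 and 3, three different substituted phenyl groups at this position therefore give numbers that cannot be told apart, including a chlorine-bearing group with fewer heavy atoms than 4-isopropylphenyl. Nothing measured here accounts for this sameness.

As far as these compounds go, whether the position stays this flat for a phenyl carrying an amine or a carboxylic acid remains open. So does the outcome with a longer alkyl chain in place of the phenyl ring.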